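Vinyl added on the chain carbon: half-life expectation

The source may hold more compounds than are shown below. What is called first, only, known or untested is meant among the compounds shown, and "the series" means these compounds.

Three compounds of the series carry numbers in an ADME assay for pharmacokinetics; a lower number here means that the compound disappears faster, a higher number that the compound lasts longer. Compound 1 `CC[C@@]1(C)C(=O)N(C(=O)NCc2ccccc2)[C@H]1Oc1ccc(C(=O)O)cc1` gives 1.8 h. Compound 2 `CC[C@@]1(C)C(=O)N(C(=O)NCc2ccccc2)[C@@H]1Oc1ccc(C(=O)O)cc1` gives 1.94 h. Compound 3 `CC(C)[C@@]1(C)C(=O)N(C(=O)NCc2ccccc2)[C@H]1Oc1ccc(C(=O)O)cc1` gives 2.43 h. Compound 1 sits at the low end of these three numbers, yet every gap to it lies within the scatter. The step of a 1.1-fold higher number from compound 1 to compound 2 (0.03 log units; within the scatter) rests on the fact that compounds 1 and 2 differ only in the configuration as drawn and shows nothing beyond the scatter. The step of a 1.4-fold higher number from compound 1 to compound 3 (0.13 log units; within the scatter), a methyl entering on a chain carbon, is likewise within the scatter.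

Compound 4 `C=CC[C@]1(CC)C(=O)N(C(=O)NCc2ccccc2)[C@H]1Oc1ccc(C(=O)O)cc1` differs from compound 1 by vinyl in place of hydrogen on a saturated chain carbon bound to a saturated ring carbon. Among the compounds with values here, the only precedent for growing this chain is a 1.4-fold higher number from compound 1 to compound 3 (0.13 log units; within the scatter), and it stayed within the scatter. Within the data shown here, the vinyl entering here is larger than that methyl, but no measured step reaches further out along the chain. On that basis compound 4 is expected to show a 1.1-fold higher number from compound 1 to compound 4 (0.05 log units; within the scatter), no step beyond the scatter. In this assay compound 4 is estimated at 2 h, with a range from 1.2 h to 3.4 h.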

Compound 4, half-life: 4.2 h
Estimate against measurement, compound 4: 2.1-fold (0.32 log units) below; the measured number lies above the stated range.
By their numbers in this assay, from the lowest: compounds 1, 2, 3 and 4 (each within the scatter of the next, the first and the last beyond it).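

In this assay, within the data shown here, the change from methyl to allyl gives the first step that lies beyond the scatter: a 2.3-fold higher number from compound 1 to compound 4 (0.37 log units; beyond the scatter). Among these compounds, the methyl entering in a 1.4-fold higher number from compound 1 to compound 3 (0.13 log units; within the scatter) stayed within the scatter, so the earlier compounds gave no sign that chain growth on the shared core could move this number, though the new step is still modest. Nothing at hand bears on why the allyl compound differs in this way.

The compounds shown leave open whether the step follows the double bond or the chain length alone, which a saturated propyl chain in the same place would separate. They also leave open whether a longer chain extends the step, and whether an amine at the chain end keeps it.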